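The compounds below may be only part of what the source reports. "The series", "measured", "known", "first", "only" and "open" are said of these compounds alone.

Compounds measured so far in a functional assay on MDA-MB-231 cells (Homo sapiens) for antiproliferative activity, read by sulforhodamine B assay, with a stated time of 72 h (a lower number here means a stronger inhibitor, a higher number a weaker inhibitor), are these:
Compound 1 `Cc1ccc(S(=O)(=O)Nc2cc(SCC(=O)N[C@@H](CC(C)C)B(O)O)c(O)c3ccccc23)cc1` gives 14000 nM
Compound 2 `CC(C)C[C@H](NC(=O)CSc1cc(NS(=O)(=O)c2ccc(Cl)cc2)c2ccccc2c1O)B(O)O` gives 6190 nM
Compound 3 `Cc1ccc(S(=O)(=O)Nc2cc(SCCC(=O)N[C@@H](CC(C)C)B(O)O)c(O)c3ccccc23)cc1` gives 6150 nM

Compound 3 and compound 2 lie within the scatter of each other, at the low end of the three numbers. Exchanging a group of 11 heavy atoms for a group of 12 heavy atoms, on a saturated chain carbon bound to a sulfur, gives a 2.3-fold lower number from compound 1 to compound 3 (0.36 log units; beyond the scatter) and sets compound 3 clearly apart from compound 1.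

Compound 4 `CC(C)C[C@H](NC(=O)CCSc1cc(NS(=O)(=O)c2ccc(Cl)cc2)c2ccccc2c1O)B(O)O` carries chloro in place of methyl on an aromatic carbon, para to a large group, and chloro in place of methyl on an aromatic carbon gives the full count. The same swap, 4-methylphenyl to 4-chlorophenyl, has been measured only once, as a 2.3-fold lower number from compound 1 to compound 2 (0.35 log units; beyond the scatter) and is the closest guide. For the measured compounds named here, no compound yet shows whether the two changes add together. A modest lowering of similar size is therefore expected, with a 2.1-fold lower number from compound 3 to compound 4 (0.31 log units; beyond the scatter) as the estimated change in this assay for this pair. For compound 4 the estimated value is 3000 nM with an expected range from 1200 nM to 7000 nM.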

Compound 4, half-maximal inhibitory concentration: 4090 nM
Compound 4: middle estimate off by 1.4-fold (0.13 log units), on the low side; the measured number falls inside the stated range.
By their numbers in this assay, from the lowest: compounds 4, 3 and 2 (each within the scatter of the next); then compound 1.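

In this assay, chloro in place of methyl on the aromatic carbon para to a large group, now read on the core of compound 3, gives a 1.5-fold lower number from compound 3 to compound 4 (0.18 log units; within the scatter) and so no longer stands clear of the scatter. The group of 12 heavy atoms in place of the group of 11 heavy atoms, read on the 4-chlorophenyl series, likewise gives a 1.5-fold lower number from compound 2 to compound 4 (0.18 log units; within the scatter). Each change thus has a second reading, and neither differs measurably between the two cores: the same change on two cores in this assay, a 2.3-fold lower number (0.35 log units; beyond the scatter) from compound 1 to compound 2 and a 1.5-fold lower number (0.18 log units; within the scatter) from compound 3 to compound 4, 1.5-fold (0.18 log units) apart, within the scatter of two such steps; (the same change on two cores in this assay, a 2.3-fold lower number (0.36 log units; beyond the scatter) from compound 1 to compound 3 and a 1.5-fold lower number (0.18 log units; within the scatter) from compound 2 to compound 4, 1.5-fold (0.18 log units) apart, within the scatter of two such steps).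

The compounds shown leave open whether a longer chain than that of compound 3 would take the number beyond the scatter. They also leave open what fluoro, trifluoromethyl or an amine would give in place of chloro at this position.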